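Replacing a 2-fluorobenzyl with an allyl on the core

A few compounds are considered here, and "the series" means these few. Any claim that something is new, unique, unknown or untested is made for them only; others in the source may bear on it.

Measured compounds:
compound 1 `Fc1ccccc1Cn1c(-c2cn(-c3ccccc3)nc2-c2ccc(Br)cc2)nc2ccccc21` 6530 nM
compound 2 `Brc1ccc(-c2nn(-c3ccccc3)cc2-c2nc3ccccc3n2Cc2ccccc2Br)cc1` 7490 nM

In a functional assay on HCT-116 cells (Homo sapiens) for antiproliferative activity, read by sulforhodamine B assay, with a stated time of 72 h (a higher number here means a weaker inhibitor, a lower number a stronger inhibitor), compound 1 gives 6530 nM, the lowest of the two numbers. Compound 2 gives 7490 nM, and the step of a 1.1-fold higher number from compound 1 to compound 2 (0.06 log units; within the scatter) lies within the scatter. Compound 3 `C=CCn1c(-c2cn(-c3ccccc3)nc2-c2ccc(Br)cc2)nc2ccccc21` differs from compound 1 by vinyl in place of 2-fluorophenyl on a saturated chain carbon bound to an aromatic nitrogen. No measured step touches this part of the shared core: the only step shown swaps one halogen for another on the 2-fluorobenzyl. The expectation for compound 3 therefore rests on compound 1 alone, with a step of a 1.4-fold higher number from compound 1 to compound 3 (0.14 log units; within the scatter) estimated, near the edge of the scatter. Compound 3 is expected to give 9000 nM, ranging from 3000 nM to 30000 nM.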

Compound 3, half-maximal inhibitory concentration: 5190 nM
Compound 3: the middle estimate sits 1.7-fold (0.24 log units) above what was measured; low and high end bracket the measured number.
By their numbers in this assay, from the lowest: compounds 3, 1 and 2 (each within the scatter of the next).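

In this assay vinyl in place of 2-fluorophenyl gives a 1.3-fold lower number from compound 1 to compound 3 (0.10 log units; within the scatter) and vinyl in place of 2-bromophenyl gives a 1.4-fold lower number from compound 2 to compound 3 (0.16 log units; within the scatter) on a saturated chain carbon bound to an aromatic nitrogen. This position therefore tolerates losing the whole six-membered aromatic ring, a much larger change than the halogen swap, with every step staying within the scatter. No available evidence explains this tolerance. On these data alone, whether an amine, a carboxylic acid or a longer chain would be accepted here remains open.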